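Hydroxy added to the fused core of compound 2

This account rests on a few compounds, and the source may have more. Where it says the series, first, only, none or still open, it means among the compounds named here.

Compound 2 `COc1cc(-c2cc3ccccc3c(=O)o2)ccc1O` stands highest of the three numbers in an assay for inhibition of Polyunsaturated fatty acid 5-lipoxygenase (Homo sapiens), read by spectrophotometry, tested at 50 uM (a lower number here means less inhibition, a higher number more inhibition at the concentration tested (going by the name of the read-out)), with 78.8%. Compound 3 `COc1ccc(-c2cc3ccccc3c(=O)o2)cc1O` is nearest, giving 65.9%; compound 1 `O=c1oc(-c2ccc(O)cc2)cc2ccccc12` is furthest, giving 34.1%. Both gaps lie beyond the scatter. For the measured compounds named here, the one step that can be computed, a number 44.7 percentage points higher from compound 1 to compound 2 (beyond the scatter), is large.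

Compound 4 `COc1cc(-c2cc3cccc(O)c3c(=O)o2)ccc1O` is not yet measured. It differs from compound 2 by hydroxy in place of hydrogen on an aromatic carbon, on the ring that is part of the fused system of two rings.

Going by the values given here, none of the measured steps bears directly on this change. The step from compound 1 to compound 2 concerns a methoxy group on the other aromatic ring, and the two values of compound 2 and compound 3 show two arrangements of methoxy and hydroxy on that same ring, not an addition to the fused core. Among the compounds with values here, no measured pair shows hydrogen replaced by hydroxy anywhere. For compound 4 the expected step is therefore a number 0.8 percentage points lower from compound 2 to compound 4 (within the scatter), with no basis for a change beyond the scatter in either direction. Compound 4 is estimated at 78%, between 58% and 93%.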

Compound 4, a percentage reported as inhibition, at one concentration (the size of the read-out at that concentration, not a potency): 35.6%
Compound 4: the middle estimate sits 42.4 percentage points above what was measured; the measured number lies below the stated range.
By their numbers in this assay, from the lowest: compounds 1 and 4 (each within the scatter of the next); then compound 3; then compound 2.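

Working notes on the fused core: in this assay this ring is no longer silent, since hydroxy in place of hydrogen on an aromatic carbon of the fused system of two rings gives a number 43.2 percentage points lower from compound 2 to compound 4 (beyond the scatter) as a large step beyond the scatter. The earlier compounds shown here varied only the other aromatic ring, and the step there, a number 44.7 percentage points higher from compound 1 to compound 2 (beyond the scatter) for methoxy in place of hydrogen, runs in the opposite direction, so the high inhibition of compound 2 does not survive this single addition to the core. Nothing at hand accounts for the drop.

On these data alone, whether the drop belongs to hydroxy itself or to any group at this place remains open, and an amine, a fluorine atom or a carboxylic acid at the same carbon would test that. Also open, as far as these compounds go, is whether hydroxy on the other carbons of this ring gives a step of similar size.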